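The source may report more compounds than this note shows. Statements on the series, on what has been measured and on what is new or still open speak of the compounds shown alone.

Compound 1, with the structure `CC(C)=CCC[C@]1(C)/C=C/[C@@H](OC(=O)C=C(C)C)[C@](C)(O)/C=C/C(=O)/C(CN(C)C)=C\C1`, is the reference for this account. Within the data shown here, in a functional assay on MCF7 cells (Homo sapiens) for antiproliferative activity, read by MTT assay, with a stated time of 48 h (a lower number here means a stronger inhibitor, a higher number a weaker inhibitor), compound 1 gives 690 nM, which is the only numerical value shown for this series. Compound 2, with the structure `CC(C)=CCC[C@]1(C)/C=C/[C@@H](OC(=O)C=C(C)C)[C@](C)(O)CCC(=O)/C(CO)=C\C1`, is the other compound measured in this assay. In this assay compound 2 gives only a limit, > 40000 nM, and no number. Among the measured compounds shown here, the two values therefore show compound 1 as the one measured compound with a defined result, while the other record is the limit described by the limit of > 40000 nM in this assay, at which 1 of the 2 values shown sits.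

Compound 3, with the structure `CSC(=S)OC/C1=C/C[C@](C)(CCC=C(C)C)/C=C/[C@@H](OC(=O)C=C(C)C)[C@](C)(O)/C=C/C1=O`, has not yet been measured. It differs from compound 1 as follows: a group of 5 heavy atoms (2 carbon, 1 oxygen, 2 sulfur; no ring) in place of a group of 3 heavy atoms (2 carbon, 1 nitrogen; no ring), on a saturated chain carbon bound to a double-bonded ring carbon. The group that enters brings more heavy atoms and more hydrogen-bond acceptors than the dimethylamino group that leaves, at the same position on the shared core.

For the measured compounds named here, no measured pair of compounds differs in one place, so there is no measured step to lean on. The expected step of a 2.9-fold higher number from compound 1 to compound 3 (0.46 log units; beyond the scatter) is toward a weaker inhibitor, of moderate size, somewhat beyond the usual scatter. Compound 3 is accordingly estimated at 2000 nM, within a range from 500 nM to 8000 nM.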

Compound 3, half-maximal inhibitory concentration: 900 nM
The estimate for compound 3 lay 2.2-fold (0.35 log units) above the measured number; the measured number falls inside the stated range.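

In this assay the change on the saturated chain carbon bound to a double-bonded ring carbon gives a 1.3-fold higher number from compound 1 to compound 3 (0.12 log units; within the scatter) and so leaves no difference that can be read between the two compounds. Among these compounds, this is the first measured step at this place, and it shows that a number in this range does not depend on the dimethylamino group, since the group of 5 heavy atoms that enters holds no nitrogen, carries oxygen and sulfur, and counts more hydrogen-bond acceptors. No measured property of either group bears on why the two compounds match, so the result gives no reason for it.

From the compounds shown here alone, how widely this place accepts other groups stays open: whether a primary amine, a morpholine ring, a carboxylic acid or a longer alkyl chain would also stay within the scatter of compound 1 cannot be told from these values. Compound 2 differs from compound 1 in more than one place, so its limit cannot be read as a step and says nothing about this position alone.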